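A few compounds are considered here, and "the series" means these few. Any claim that something is new, unique, unknown or untested is made for them only; others in the source may bear on it.

Compound 1 `C/C=C/C=C/C(=O)N(Cc1ccc(OC)c(O)c1)c1cc(OC)c(OC)c(OC)c1` is the more potent of the two compounds measured here. In a functional assay on KYSE-450 cells (Homo sapiens) for inhibition, read by MTT assay, with a stated time of 48 h (on this read-out higher numbers stand for weaker inhibition and lower numbers for stronger inhibition), compound 1 gives 180 nM, the lowest of the two numbers. Within the data shown here, the only comparison is with compound 2 `COc1ccc(N(Cc2cc(OC)c(OC)c(OC)c2)C(=O)CN=[N+]=[N-])cc1O`, which in this assay gives 26100 nM; that gap lies well beyond the usual scatter, so compound 1 stands clearly apart from compound 2 on this read-out. Among the measured compounds shown here, no single-point step between measured compounds has been established, so the data give no direct sense of how changes at the acyl chain move the number.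

Compound 3 `COc1ccc(CN(C(=O)/C=C/CBr)c2cc(OC)c(OC)c(OC)c2)cc1O` shares the core of compound 1 and differs only at the acyl chain: bromomethyl in place of prop-1-en-1-yl on a double-bonded chain carbon bound to a double-bonded chain carbon. Cut one bond further out, the change reads penta-1,3-dien-1-yl to 3-bromoprop-1-en-1-yl on the carbonyl.

For the measured compounds named here, with no measured step of this kind to lean on, the expectation for compound 3 is a modest move toward weaker inhibition, a step of a 2.2-fold higher number from compound 1 to compound 3 (0.35 log units; beyond the scatter) that may not exceed the scatter. Compound 3 is therefore expected to give about 400 nM, with a range from 80 nM to 3000 nM.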

Compound 3, half-maximal inhibitory concentration: 100 nM
Estimate against measurement, compound 3: 4.0-fold (0.60 log units) above, and the stated range covers the measured number.
By their numbers in this assay, from the lowest: compounds 3 and 1 (each within the scatter of the next); then compound 2.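

In this assay, among these compounds, putting bromomethyl in place of prop-1-en-1-yl on a double-bonded chain carbon bound to a double-bonded chain carbon gives (a 1.8-fold lower number from compound 1 to compound 3 (0.26 log units; within the scatter)), the first single-place step at this position, and it does not separate the two compounds. This pair shows that the acyl chain can go from penta-1,3-dien-1-yl to 3-bromoprop-1-en-1-yl, losing one double bond outside aromatic rings and gaining a bromine, while the number stays within the usual scatter of this read-out. The data offer no measured basis for explaining why the two compounds read alike.

As far as these compounds go, a single step cannot show how much of this position's tolerance extends to other groups, so what chloromethyl, hydroxymethyl, an aminomethyl group or a longer alkyl chain would do at this place remains open. From the compounds shown here alone, it also remains open whether the bromine or the remaining chain double bond contributes to the number, as this one change leaves the two contributions unseparated.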